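Indolyl to dimethylaminophenyl on the shared core

This account rests on a few compounds, and the source may have more. Where it says the series, first, only, none or still open, it means among the compounds named here.

Values so far in a functional assay on B16-F0 cells (Mus musculus) for inhibition, read by CCK-8 assay, with a stated time of 48 h; on this read-out lower numbers stand for stronger inhibition and higher numbers for weaker inhibition:
- compound 1 `COc1cc(-c2ccnc3cc(-c4c[nH]c5ccccc45)nn23)cc(OC)c1OC` gives 40 nM
- compound 2 `COc1cc(-c2ccnc3cc(-c4ccc(C)c(C)c4)nn23)cc(OC)c1OC` gives 391 nM
- compound 3 `COc1cc(-c2ccnc3cc(-c4ccc5c(ccn5C)c4)nn23)cc(OC)c1OC` gives 48 nM

Compound 3, at 48 nM, shares the low end of the range with compound 1. The two indolyl groups are matched, with a 1.2-fold higher number from compound 1 to compound 3 (0.08 log units; within the scatter). The gap to the phenyl example is larger, with an 8.1-fold lower number from compound 2 to compound 3 (0.91 log units; beyond the scatter).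

The next entry is compound 4 `COc1cc(-c2ccnc3cc(-c4ccc(N(C)C)cc4)nn23)cc(OC)c1OC`, where 4-(dimethylamino)phenyl takes the place of 1-methyl-1H-indol-5-yl on an aromatic carbon of the five-membered aromatic ring: 4-(dimethylamino)phenyl in place of 1-methyl-1H-indol-5-yl on an aromatic carbon.

Going by the values given here, the closest guide is compound 2, the only measured compound with a substituted phenyl group, and the relevant steps are a 9.8-fold higher number from compound 1 to compound 2 (0.99 log units; beyond the scatter) and an 8.1-fold lower number from compound 2 to compound 3 (0.91 log units; beyond the scatter) already noted. Read in reverse, these point to a rise in this assay on leaving the indolyl group. One phenyl example is thin support, and its substituents differ from the dimethylamino group, so only part of that size is expected. The expected step is a 3.3-fold higher number from compound 3 to compound 4 (0.52 log units; beyond the scatter). The estimated value for compound 4 is 160 nM, with an expected range of 50 nM to 500 nM.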

Compound 4, half-maximal inhibitory concentration: 702 nM
Beside the measured number, compound 4's estimate is 4.4-fold (0.64 log units) below it; the whole stated range lies below it.
By their numbers in this assay, from the lowest: compounds 1 and 3 (each within the scatter of the next); then compounds 2 and 4 (each within the scatter of the next).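

In this assay, moving from either indolyl group to 4-(dimethylamino)phenyl at this carbon of the five-membered aromatic ring gives a 15-fold higher number from compound 3 to compound 4 (1.17 log units; beyond the scatter) and an 18-fold higher number from compound 1 to compound 4 (1.24 log units; beyond the scatter) so the change is large from both indolyl starting points. Compound 4 also stands level with the other substituted phenyl example, with a 1.8-fold higher number from compound 2 to compound 4 (0.25 log units; within the scatter) so among these four compounds the two indolyl groups form the low pair and the two substituted phenyl groups the high pair, with no compound going against that split, although dimethylamino and 3,4-dimethyl are very different substituents. 1-Methyl-1H-indol-5-yl and 4-(dimethylamino)phenyl carry the same counts of hydrogen-bond donors and acceptors, so those counts do not separate them, and no measurement at hand accounts for the gap.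

Still open, on these data alone, is whether the low numbers depend on the indole nitrogen or only on the two fused rings, a question that a naphthalen-2-yl group at this carbon would address. As far as these compounds go, it is also open whether any single phenyl ring can reach the indolyl level, for example one carrying a hydroxyl or a methoxy group.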